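A Bromo Group Joins the Shared Core

A few compounds are considered here, and "the series" means these few. Any claim that something is new, unique, unknown or untested is made for them only; others in the source may bear on it.

Measured in a functional assay on SW-620 cells (Homo sapiens); a higher number here means a weaker inhibitor of growth, a lower number a stronger inhibitor of growth:
Compound 1 `O=S(=O)(/C=C/c1ccc(F)cc1)Cc1ccc(Nc2ncnc3ccccc23)cc1`: 100000 nM
Compound 2 `O=S(=O)(/C=C/c1ccc(F)cc1F)Cc1ccc(Nc2ncnc3ccccc23)cc1`: 86000 nM
Compound 3 `O=S(=O)(/C=C/c1ccc(C(F)(F)F)cc1F)Cc1ccc(Nc2ncnc3ccccc23)cc1`: 100000 nM

Compound 3 stands at 100000 nM, level with compound 1 at 100000 nM. Compound 2 differs from it only within the scatter, with a 1.2-fold higher number from compound 2 to compound 3 (0.07 log units; within the scatter). Compound 4 `O=S(=O)(/C=C/c1ccc(C(F)(F)F)cc1F)Cc1ccc(Nc2ncnc3ccc(Br)cc23)cc1` keeps everything in compound 3 except one change: bromo in place of hydrogen on an aromatic carbon. Among the compounds with values here, no measured step touches the shared core, so the evidence is only indirect. The nearest one, also a halogen replacing hydrogen, gave a 1.2-fold lower number from compound 1 to compound 2 (0.07 log units; within the scatter). The other steps gave no change at the digits printed from compound 1 to compound 3 (within the scatter) and a 1.2-fold higher number from compound 2 to compound 3 (0.07 log units; within the scatter). Only a small change, not clearly beyond the scatter, is therefore expected in this assay: a 1.7-fold lower number from compound 3 to compound 4 (0.22 log units; within the scatter). The estimate for compound 4 is 60000 nM, with an expected range of 15000 nM to 120000 nM.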

Compound 4, concentration for 50% growth inhibition: 55000 nM
Compound 4: middle estimate off by 1.1-fold (0.04 log units), on the high side, and the stated range covers the measured number.
By their numbers in this assay, from the lowest: compounds 4, 2, 1 and 3 (each within the scatter of the next).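

The step on the shared core, bromo in place of hydrogen on an aromatic carbon, gives a 1.8-fold lower number from compound 3 to compound 4 (0.26 log units; within the scatter) in this assay, so this position accepts a bromo group without a step beyond the scatter. The earlier steps shown here left the shared core untouched, and this one gives the first direct reading there, with all four compounds still each within the scatter of the next. No available evidence bears on this result. On these data alone, whether an amine or a methoxy group at this position would move the number beyond the scatter remains open. So does whether bromo would behave alike alongside the side chains of compound 1 or compound 2.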